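The source may report more compounds than this note shows. Statements on the series, on what has been measured and on what is new or still open speak of the compounds shown alone.

Compound 2 (`CN(C[C@H]1Cc2c(cccc2N2CCNC(C)(C)C2)CN1)[C@H]1CCCc2cccnc21`) belongs to a set of three measured compounds tested in a functional assay on CCRF-CEM cells for antagonist activity at C-X-C chemokine receptor type 4 (Homo sapiens), read by calcium flux, with stated times of 25 min and 90 s; a lower number here means a stronger inhibitor, a higher number a weaker inhibitor. In this assay compound 2 gives 33.9 nM, the highest of the three numbers. Compound 1 (`Cc1cnc(CN(C)C[C@H]2Cc3c(cccc3N3CCNCC3)CN2)c(C)c1`) gives 21.4 nM in this assay, which sits within the scatter of the number for compound 2. Compound 3 (`CN(C[C@H]1Cc2c(cccc2N2CCN(Cc3ccccn3)CC2)CN1)[C@H]1CCCc2cccnc21`) gives 4.47 nM in this assay, a gap from compound 2 that lies beyond the scatter. No pair of these compounds differs in a single place, so no step between measured compounds can be read off.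

Compound 4 (`CN(C[C@H]1Cc2c(cccc2N2CCN3CCC[C@@H]3C2)CN1)[C@H]1CCCc2cccnc21`) has not yet been measured. It differs from compound 2 in one place: a group of 9 heavy atoms (7 carbon, 2 nitrogen; one five-membered non-aromatic ring with 1 hetero atom, one six-membered non-aromatic ring with 2 hetero atoms) in place of a group of 8 heavy atoms (6 carbon, 2 nitrogen; one six-membered non-aromatic ring with 2 hetero atoms), on an aromatic carbon. For the measured compounds named here, the only guidance comes from compound 3, whose value of 4.47 nM shows that a substituted piperazine at that carbon can go with a lower number than compound 2 shows. The step from compound 2 to compound 4 is therefore expected to be a modest decrease, a 2.3-fold lower number from compound 2 to compound 4 (0.35 log units; beyond the scatter), close to the edge of the scatter. Compound 4 is estimated at 15 nM in this assay, within a range from 5 nM to 45 nM.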

Compound 4, half-maximal inhibitory concentration: 3.59 nM
For compound 4 the middle estimate is 4.2-fold (0.62 log units) above the measured one; measured number outside the range, below it.
By their numbers in this assay, from the lowest: compounds 4 and 3 (each within the scatter of the next); then compounds 1 and 2 (each within the scatter of the next).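

At this aromatic carbon of the shared core, this assay shows a 9.4-fold lower number from compound 2 to compound 4 (0.98 log units; beyond the scatter), so a group with one five-membered and one six-membered non-aromatic ring can take the place of 3,3-dimethylpiperazin-1-yl with a lower number. The change alters several things at once: a five-membered ring is added, 0 hydrogen-bond donors replace 1, and a defined stereocentre enters, so the step cannot be assigned to any one of these. Nothing available explains why the number falls.

The compounds shown leave open how much of the step depends on the stereocentre, since the opposite arrangement at that centre does not appear among them. They also leave open whether a morpholine ring or an open-chain dimethylamino group at this carbon would give a similar number.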